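Pyrrolidin-3-yl in Place of Isopentyl: Cytotoxicity Outlook

The compounds below may be only part of what the source reports. "The series", "measured", "known", "first", "only" and "open" are said of these compounds alone.

Compound 1 `CC(C)CCn1nc(C(=O)N[C@H]2COc3ccccc3N(C)C2=S)nc1Cc1ccccc1`: > 100000 nM
Compound 2 `CN1C(=S)[C@@H](NC(=O)c2nc(Cc3ccccc3)n(CCCC#N)n2)COc2ccccc21`: > 100000 nM
Compound 3 `CN1C(=S)[C@@H](NC(=O)c2nc(Cc3ccccc3)n(CC3CCOCC3)n2)COc2ccccc21`: > 100000 nM

In a toxicity assay on HT-29 cells (Homo sapiens) for cytotoxicity (a higher number here means that more compound is tolerated, a lower number that less compound is tolerated), compound 1 gives only a limit, > 100000 nM, and not a number. Compound 2 likewise reaches only a limit, > 100000 nM. Compound 3 also stops at a limit, > 100000 nM. Compound 1 therefore stands together with the other two at the limit of > 100000 nM in this assay, at which 3 of the 3 values shown sit, and none of the three values can be placed above or below another.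

Compound 4 `CN1C(=S)[C@@H](NC(=O)c2nc(Cc3ccccc3)n(C3CCNC3)n2)COc2ccccc21` differs from compound 1 by pyrrolidin-3-yl in place of isopentyl on an aromatic nitrogen. The change sits on the same aromatic nitrogen where the three measured compounds differ among themselves. The steps there, a step that the two limits leave unreadable from compound 1 to compound 2, a step that the two limits leave unreadable from compound 1 to compound 3 and a step that the two limits leave unreadable from compound 2 to compound 3, are all unreadable: both ends of each step are limits, so they give neither a size nor a direction. Saturated chains and the oxan-4-yl ring alike left the read-out at the limit.

Because all three measured values sit at the limit of > 100000 nM in this assay, at which 3 of the 3 values shown sit, compound 4 is expected to sit at the limit as well, and the step that the limit leaves unreadable from compound 1 to compound 4 is expected to be nothing beyond the scatter. Compound 4 is thus estimated at 150000 nM, with a range from 50000 nM to 400000 nM.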

Compound 4, half-maximal cytotoxic concentration: > 100000 nM
Compound 4: a limit, no number (the forecaster's own chance of this, stated with the estimate: 80%); the middle value does not contradict the limit.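

In this assay compound 4 gives only a limit, > 100000 nM. None of its steps from compound 1, compound 2 or compound 3 can be read, and all four compounds stand together: the limit of > 100000 nM in this assay, at which 4 of the 4 values shown sit. The compounds shown leave open how far beyond the limit each one lies, and whether the group on the aromatic nitrogen matters in this read-out at all.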